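The source may hold more compounds than are shown below. What is called first, only, known or untested is meant among the compounds shown, and "the series" means these compounds.

Compound 1 `CCC(=O)N1C[C@@H](O[C@H](C)c2cc(C(F)(F)F)cc(C(F)(F)F)c2)[C@H](c2ccc(F)cc2)C1` and compound 2 `C[C@@H](O[C@@H]1CN(C(=O)[C@@H]2COC(=O)N2)C[C@H]1c1ccc(F)cc1)c1cc(C(F)(F)F)cc(C(F)(F)F)c1` share a core, and in an assay on CHO cells for displacement of a labelled ligand from Substance-P receptor (Homo sapiens) (on this read-out higher numbers stand for weaker inhibition and lower numbers for stronger inhibition), compound 1 gives 0.09 nM while compound 2 gives 0.34 nM. Going by the values given here, the one measured step, a 3.8-fold higher number from compound 1 to compound 2 (0.58 log units; beyond the scatter), swaps the ethyl on the carbonyl carbon for a 2-oxo-1,3-oxazolidin-4-yl. Compound 2 therefore stands at the higher of the two numbers, with compound 1 the nearer and only neighbour.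

Compound 3 `C[C@@H](O[C@@H]1CN(C(=O)N(C)C)C[C@H]1c1ccc(F)cc1)c1cc(C(F)(F)F)cc(C(F)(F)F)c1` takes the step onward: dimethylamino in place of 2-oxo-1,3-oxazolidin-4-yl on a carbonyl carbon. The entering group brings no ring, no hydrogen-bond donor and no hydrogen-bond acceptor, so the carbonyl now carries a dimethylcarbamoyl rather than the ring-bearing group of compound 2. Among the compounds with values here, only the step from compound 1 to compound 2 bears on this change, and it ran in the direction of a higher number when the ring entered. Within the data shown here, removing that ring again is expected to move the number back toward that of compound 1, by a step of roughly a 2.3-fold lower number from compound 2 to compound 3 (0.36 log units; beyond the scatter), though with only one step to lean on the size is uncertain. Compound 3 is estimated at 0.15 nM, within a range from 0.05 nM to 0.5 nM.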

Compound 3, half-maximal inhibitory concentration: 0.38 nM
Compound 3: the middle estimate sits 2.5-fold (0.40 log units) below what was measured; the range from low to high includes it.
By their numbers in this assay, from the lowest: compound 1; then compounds 2 and 3 (each within the scatter of the next).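

In this assay the exchange of 2-oxo-1,3-oxazolidin-4-yl for dimethylamino on the carbonyl carbon gives a 1.1-fold higher number from compound 2 to compound 3 (0.05 log units; within the scatter) and so does not separate the two groups, although the entering group has no ring, no hydrogen-bond donor and no hydrogen-bond acceptor. Measured against ethyl at the same place, dimethylamino gives a 4.2-fold higher number from compound 1 to compound 3 (0.63 log units; beyond the scatter) and the ring-bearing group gave a 3.8-fold higher number from compound 1 to compound 2 (0.58 log units; beyond the scatter) before it, so among these three compounds ethyl stands apart with compound 1 at the lowest number, whether or not the group that replaces it carries a ring. Nothing at hand explains why two such different groups give values within the scatter of each other.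

As far as these compounds go, it remains open whether an amine such as pyrrolidine or methylamino on the same carbonyl carbon, or a longer chain such as propyl or butyl in place of ethyl, would fall with compound 1 or with compound 2 and compound 3. The opposite stereocentre in the 2-oxo-1,3-oxazolidin-4-yl group is also left open, as is any reading of this position on another core.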